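The source may report more compounds than this note shows. Statements on the series, on what has been measured and on what is new or still open speak of the compounds shown alone.

Compound 1, `O=S(=O)(Nc1ccc(F)c(C#Cc2cnc3[nH]ncc3c2)c1F)c1cccc(F)c1`, reported in a functional assay on HCT-116 cells (Homo sapiens) for antiproliferative activity, read by MTT assay, with a stated time of 68 h (a higher number here means a weaker inhibitor, a lower number a stronger inhibitor), only as a limit, > 10000 nM.
Compound 2, `O=S(=O)(Nc1ccc(F)c(C#Cc2cnc3[nH]ncc3c2)c1F)c1cccnc1`, reported in this assay only as a limit, > 10000 nM.

Both measured compounds share the same core and the same fluorinated aniline sulfonamide, and differ only in the aryl group on the sulfonyl sulfur. Going by the values given here, the one measured step, a step that the two limits leave unreadable from compound 1 to compound 2, cannot be read, because of the limit of > 10000 nM in this assay, at which 2 of the 2 values shown sit. Compound 2 therefore stands in this assay without a number of its own: all that is known is that it is a weak inhibitor at best, and compound 1 gives no firmer footing.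

Compound 3, `O=S(=O)(Nc1ccc(F)c(C#Cc2cnc3[nH]nc(-c4ccccc4)c3c2)c1F)c1cccnc1`, differs from compound 2 by phenyl in place of hydrogen on an aromatic carbon. Among the compounds with values here, this change sits on the fused bicyclic core, far from the sulfonyl group that the single measured step concerns, so no measured step bears on it, and that step was itself unreadable. There is thus no basis in the measured compounds for expecting a step in this assay in either direction beyond the scatter, and the starting point is a limit rather than a value. Compound 3 is estimated at 8000 nM, within 1000 nM to 40000 nM, which means an expected step of an at least 1.2-fold lower number from compound 2 to compound 3 (0.09 log units; that floor lies within the scatter).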

Compound 3, half-maximal inhibitory concentration: > 10000 nM
Compound 3: no number, only a limit; the forecaster's own chance of this, stated with the estimate: 55%; middle value at least 1.2-fold (0.09 log units) away from the limit.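

Compound 3, like compound 2, is reported only as a limit, so no step can be read between compound 2 and compound 3, because neither has a number of its own: the limit of > 10000 nM in this assay, at which 3 of the 3 values shown sit. The compounds shown leave open how these three compare in this assay and whether phenyl in place of hydrogen changes their activity there at all.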